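A Single Fluorine on the Central Ring of Compound 1

This account rests on a few compounds, and the source may have more. Where it says the series, first, only, none or still open, it means among the compounds named here.

Compound 1 `O=C(Nc1ccc(Oc2ccnc3[nH]ccc23)cc1)c1cn(-c2ccccc2)c2ccccc2c1=O` is the starting point. In a functional assay on MCF7 cells (Homo sapiens) for inhibition, read by MTT assay, with a stated time of 72 h (on this read-out higher numbers stand for weaker inhibition and lower numbers for stronger inhibition), compound 1 gives 3560 nM, the second highest of three numbers. Compound 3 `COc1ccc(-n2cc(C(=O)Nc3ccc(Oc4ccnc5[nH]ccc45)cc3)c(=O)c3ccccc32)cc1` gives 4650 nM in this assay, and the difference a 1.3-fold higher number from compound 1 to compound 3 (0.12 log units; within the scatter) lies within the scatter. Compound 2 `O=C(Nc1ccc(Oc2ccnc3[nH]ccc23)cc1)c1cn(-c2ccc(F)c(Cl)c2)c2ccccc2c1=O` gives 1510 nM, and the step of a 2.4-fold lower number from compound 1 to compound 2 (0.37 log units; beyond the scatter) counts as modest. Compound 4 `O=C(Nc1ccc(Oc2ccnc3[nH]ccc23)c(F)c1)c1cn(-c2ccccc2)c2ccccc2c1=O` differs from compound 1 by fluoro in place of hydrogen on an aromatic carbon, on a six-membered aromatic ring of carbon only, ortho to a large group and meta to a large group. Within the data shown here, no measured step touches this ring; the closest comparison is a 2.4-fold lower number from compound 1 to compound 2 (0.37 log units; beyond the scatter), where halogens entered a different ring. For compound 4 the step expected is a 1.2-fold lower number from compound 1 to compound 4 (0.07 log units; within the scatter), probably within the scatter. Compound 4 is estimated at 3000 nM, between 1200 nM and 7500 nM.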

Compound 4, half-maximal inhibitory concentration: 430 nM
The estimate for compound 4 lay 7.0-fold (0.84 log units) above the measured number; the measured number lies below the stated range.
By their numbers in this assay, from the lowest: compound 4; then compound 2; then compounds 1 and 3 (each within the scatter of the next).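

Fluoro in place of hydrogen on this six-membered aromatic ring of carbon only gives an 8.3-fold lower number from compound 1 to compound 4 (0.92 log units; beyond the scatter) in this assay. This shows that the ring, untouched in compounds 1, 2 and 3, responds to a change of one heavy atom. No measurement available here explains the drop.

The compounds shown leave open whether a methyl group or an amine at the same place would lower the number too. They also leave open how fluoro here would combine with the 3-chloro-4-fluorophenyl group of compound 2.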